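Triazole substituent variation on the shared core

A few compounds are considered here, and "the series" means these few. Any claim that something is new, unique, unknown or untested is made for them only; others in the source may bear on it.

Compounds measured so far, with the group on the triazole carbon:
Compound 1 `CO[C@@H]1[C@@H](O)[C@@H](O)[C@H](Oc2ccc3c(c2C)OC(=O)C(n2cc(-c4ccccc4)nn2)C3)OC1(C)C`: in a functional assay on MCF7 cells (Homo sapiens) for antiproliferative activity (a higher number here means a weaker inhibitor, a lower number a stronger inhibitor), compound 1 gives 64400 nM.
Compound 2 `CO[C@@H]1[C@@H](O)[C@@H](O)[C@H](Oc2ccc3c(c2C)OC(=O)C(n2cc(-c4ccc(C)cc4)nn2)C3)OC1(C)C`: compound 2 reaches only a limit of this assay, > 100000 nM.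
Compound 3 `CO[C@@H]1[C@@H](O)[C@@H](O)[C@H](Oc2ccc3c(c2C)OC(=O)C(n2cc(/C=C/c4ccccc4)nn2)C3)OC1(C)C`: in this assay compound 3 gives 14600 nM.

Compound 3 holds the lowest of the two numbers; the nearest is compound 1, by a 4.4-fold lower number from compound 1 to compound 3 (0.64 log units; beyond the scatter). Compound 2 sits at a limit (the limit of > 100000 nM in this assay, at which 1 of the 3 values shown sits); against it, an at least 6.8-fold lower number from compound 2 to compound 3 (0.83 log units; beyond the scatter).

Compound 4 `CO[C@@H]1[C@@H](O)[C@@H](O)[C@H](Oc2ccc3c(c2C)OC(=O)C(n2cc(-c4c[nH]c5ccccc45)nn2)C3)OC1(C)C` carries 1H-indol-3-yl in place of 2-phenylethenyl on an aromatic carbon. Going by the values given here, the steps that bear on this are the two exchanges at the same carbon, a 4.4-fold lower number from compound 1 to compound 3 (0.64 log units; beyond the scatter) and an at least 6.8-fold lower number from compound 2 to compound 3 (0.83 log units; beyond the scatter), both modest and beyond the scatter, while an at least 1.5-fold higher number from compound 1 to compound 2 (0.19 log units; that floor lies within the scatter) stays within it. The 2-phenylethenyl gave the lowest number, so a modest rise is expected, a 1.7-fold higher number from compound 3 to compound 4 (0.23 log units; within the scatter). Compound 4 is estimated at 25000 nM, range 7000 nM to 90000 nM.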

Compound 4, half-maximal inhibitory concentration: 18300 nM
Compound 4: middle estimate off by 1.4-fold (0.14 log units), on the high side, and the stated range covers the measured number.
By their numbers in this assay, from the lowest: compounds 3 and 4 (each within the scatter of the next); then compound 1. At a limit, above all of these: compound 2.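

In this assay, 1H-indol-3-yl on the triazole carbon also gives a number under that of phenyl: a 3.5-fold lower number from compound 1 to compound 4 (0.55 log units; beyond the scatter). So 2-phenylethenyl is not alone at this position, and the two groups, one with a hydrogen-bond donor and one without, are not separated: a 1.3-fold higher number from compound 3 to compound 4 (0.10 log units; within the scatter). Against compound 2 the step is only a floor, an at least 5.4-fold lower number from compound 2 to compound 4 (0.73 log units; beyond the scatter), and compound 2 itself stands at a limit: the limit of > 100000 nM in this assay, at which 1 of the 4 values shown sits.

Going by these compounds, whether the indole ring hydrogen matters stays open, and 1-methylindol-3-yl would address it. On these data alone, how an amine or a carboxylic acid on the phenyl ring of compound 1 would read also remains open.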